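Carboxybenzyl in place of thiazolylmethyl at the ring nitrogen

The source may report more compounds than this note shows. Statements on the series, on what has been measured and on what is new or still open speak of the compounds shown alone.

Compound 1 `Clc1cc(Cl)cc(CO[C@H]2CCCN(Cc3nccs3)[C@H]2c2ccccc2)c1` — > 200000 nM
Compound 2 `CN1CCC[C@H](O[C@H](CO)c2cc(Cl)cc(Cl)c2)[C@@H]1c1ccccc1` — 42000 nM

In an assay on isolated protein for activation of cGMP-dependent protein kinase 1 (Homo sapiens), read by ADP-Glo, with stated times of 120 min and 40 min (on this read-out higher numbers stand for an effect only at larger amounts of compound and lower numbers for an effect already at smaller amounts), compound 1 gives only a limit, > 200000 nM, which is the value at which it stands in the set (the limit of > 200000 nM in this assay, at which 1 of the 2 values shown sits). In this assay compound 2 gives 42000 nM. Compound 3 `O=C(O)c1ccc(CN2CCC[C@H](OCc3cc(Cl)cc(Cl)c3)[C@@H]2c2ccccc2)cc1` differs from compound 1 in one place: 4-carboxyphenyl in place of 1,3-thiazol-2-yl on a saturated chain carbon bound to an amine nitrogen in a ring. Going by the values given here, no measured pair shows this change, so the expected step of an at least 2.0-fold lower number from compound 1 to compound 3 (0.30 log units; that floor lies within the scatter) is modest, toward an effect at smaller amounts, and may not reach beyond the scatter. For compound 3 the estimate is 100000 nM, ranging from 30000 nM to 300000 nM.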

Compound 3, half-maximal effective concentration: 76000 nM
Compound 3: the middle estimate sits 1.3-fold (0.12 log units) above what was measured; measured number inside the range.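

In this assay, the ring nitrogen's substituent proves able to change the read-out: 4-carboxyphenyl in place of 1,3-thiazol-2-yl gives an at least 2.6-fold lower number from compound 1 to compound 3 (0.42 log units; beyond the scatter). Compounds 1 and 2 differ in more than one place, so they could not show this for a single change. The value of compound 1 is a limit, so this step has only a floor: the limit of > 200000 nM in this assay, at which 1 of the 3 values shown sits.

The compounds shown leave open whether the carboxylic acid or the phenyl ring carrying it accounts for the step. A plain benzyl group or a primary amide at this place would separate the two.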